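Benzylation of the amide nitrogen in compound 3

The compounds below may be only part of what the source reports. "The series", "measured", "known", "first", "only" and "open" are said of these compounds alone.

For the measured compounds named here, compound 3 `NC(=O)c1ccc2c(ccn2-c2ccc(NC(=O)c3ccc(Cl)c(C(F)(F)F)c3)cc2)n1` gives 8900 nM in a functional assay on A375P cells (Homo sapiens) for cytotoxicity, read by MTT assay (a lower number here means a stronger inhibitor, a higher number a weaker inhibitor), the only number among the three compounds measured. Compound 2 `NC(=O)c1ccc2c(ccn2-c2ccc(NC(=O)c3cccc(C(F)(F)F)c3)cc2)n1` gives > 10000 nM, a limit of this assay. Compound 1 `O=C(Nc1ccc(-n2ccc3nc(C(=O)NCc4ccccc4)ccc32)cc1)Nc1cccc(Cl)c1Cl` gives > 10000 nM, also a limit. Going by the values given here, the only measured step, an at least 1.1-fold lower number from compound 2 to compound 3 (0.05 log units; that floor lies within the scatter), rests on the limit of > 10000 nM in this assay, at which 2 of the 3 values shown sit, and does not touch the amide nitrogen. Compound 4 `O=C(Nc1ccc(-n2ccc3nc(C(=O)NCc4ccccc4)ccc32)cc1)c1ccc(Cl)c(C(F)(F)F)c1` differs from compound 3 by benzyl in place of hydrogen on an amide-type nitrogen. Among the compounds with values here, no measured step covers this change; compound 1, which carries the same benzylcarbamoyl group on a urea-bearing analogue, shows only a limit. For compound 4 the step of a 1.0-fold higher number from compound 3 to compound 4 (0.00 log units; within the scatter) is therefore expected to be small and of uncertain direction. Compound 4 is estimated at 9000 nM, within 3000 nM to 30000 nM, with a fair chance of a limit only.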

Compound 4, half-maximal inhibitory concentration: 700 nM
Compound 4: the middle estimate sits 13-fold (1.11 log units) above what was measured; the whole stated range lies above it.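

Benzyl in place of hydrogen on the amide-type nitrogen gives a 13-fold lower number from compound 3 to compound 4 (1.10 log units; beyond the scatter) in this assay, the first step in the series beyond the scatter. With benzylcarbamoyl held constant, 4-chloro-3-(trifluoromethyl)phenyl in place of (2,3-dichlorophenyl)amino on the carbonyl carbon gives an at least 14-fold lower number from compound 1 to compound 4 (1.15 log units; beyond the scatter) as a floor only. Compound 1 gives > 10000 nM in this assay, which is a limit and not a number.

Open, going by these compounds, is whether the aromatic ring of benzyl is needed, a question for methyl or a longer chain such as phenethyl on the same nitrogen. Also open, on these data alone, is whether an amine or a carboxylic acid on the benzyl ring would keep the level of compound 4.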